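This account rests on a few compounds, and the source may have more. Where it says the series, first, only, none or still open, it means among the compounds named here.

Measured in a functional assay on MCF7 cells (Homo sapiens) for antiproliferative activity, read by MTT assay, with a stated time of 48 h; on this read-out higher numbers stand for weaker inhibition and lower numbers for stronger inhibition:
- compound 1, `O=C(/C=C/c1ccc(O)c(O)c1)N1CCN(c2ccccc2Cl)CC1`: 1.36 ug/mL
- compound 2, `COc1ccccc1N1CCN(C(=O)/C=C/c2ccc(O)c(O)c2)CC1`: 0.54 ug/mL
- compound 3, `COc1ccc(N2CCN(C(=O)/C=C/c3ccc(O)c(O)c3)CC2)cc1`: 0.52 ug/mL

Compound 1 carries the highest number of the three. The nearest of the measured steps is a 2.5-fold lower number from compound 1 to compound 2 (0.40 log units; beyond the scatter); the furthest is a 2.6-fold lower number from compound 1 to compound 3 (0.42 log units; beyond the scatter). Between the two methoxy compounds the difference is a 1.0-fold lower number from compound 2 to compound 3 (0.02 log units; within the scatter), so compound 2 and compound 3 cannot be ordered.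

Compound 4, `O=C(/C=C/c1ccc(O)c(O)c1)N1CCN(c2ccccn2)CC1`, is not yet measured. It differs from compound 1 in one place: pyridin-2-yl in place of 2-chlorophenyl on an amine nitrogen in a ring. Both measured steps that leave compound 1 bear on it, since each removes the 2-chlorophenyl group and each lowered the number by a modest amount beyond the scatter. Neither step brings in a pyridin-2-yl group, so the direction is supported only by analogy. For compound 4 a modest lowering or no change beyond the scatter is expected, as a 1.4-fold lower number from compound 1 to compound 4 (0.16 log units; within the scatter). The estimate for compound 4 in this assay is 0.95 ug/mL, within 0.4 ug/mL to 2.3 ug/mL.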

Compound 4, half-maximal inhibitory concentration: 1.82 ug/mL
Compound 4: middle estimate off by 1.9-fold (0.28 log units), on the low side, within the range that was stated.
By their numbers in this assay, from the lowest: compounds 3 and 2 (each within the scatter of the next); then compounds 1 and 4 (each within the scatter of the next).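

In this assay, replacing 2-chlorophenyl with pyridin-2-yl on the amine nitrogen in the ring leaves the number within the scatter (a 1.3-fold higher number from compound 1 to compound 4 (0.13 log units; within the scatter)), so losing 2-chlorophenyl does not by itself lower the number. The methoxy-bearing groups remain apart from pyridin-2-yl (a 3.5-fold higher number from compound 3 to compound 4 (0.54 log units; beyond the scatter); a 3.4-fold higher number from compound 2 to compound 4 (0.53 log units; beyond the scatter)), so among the four compounds the lower numbers go with 2-methoxyphenyl and 4-methoxyphenyl, and compound 1 and compound 4 lack them. No measurement at hand accounts for this split.

The compounds shown leave open whether a 4-chlorophenyl group would stay with compound 1 or join the methoxy compounds. An unsubstituted phenyl group and a methoxy-substituted pyridine on the same nitrogen would show whether the methoxy group or the carbon-only aromatic ring tracks with the lower numbers.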